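The source may report more compounds than this note shows. Statements on the series, on what has been measured and on what is new or still open speak of the compounds shown alone.

Measured so far:
compound 1 `O=C(NCC1CCc2n[nH]cc2C1)[C@@H]1CCCN1C(=O)[C@@H](CC1CCCCC1)NS(=O)(=O)Cc1ccccc1`, for which an assay on isolated protein for inhibition of serine protease 1 (Homo sapiens) (on this read-out lower numbers stand for stronger inhibition and higher numbers for weaker inhibition), gives > 68300 nM, which is a limit of the assay and not a number
compound 2 `O=C(NC1CCc2c[nH]cc2C1)[C@@H]1CCCN1C(=O)[C@@H](CC1CCCCC1)NS(=O)(=O)Cc1ccccc1`, for which this assay gives 416000 nM

Compound 1 stands only as a limit in this assay: the value recorded for compound 1 sits at the limit of > 68300 nM in this assay, at which 1 of the 2 values shown sits, so its true inhibition constant is not known, only a bound on it. For the measured compounds named here, the single measured step, a step that the limit leaves unreadable from compound 1 to compound 2, is therefore unreadable in size; all that compound 2 shows is that a weak inhibitor remains weak when its ring group is exchanged.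

Compound 3 `Nc1ncc2c(n1)CCC(NC(=O)[C@@H]1CCCN1C(=O)[C@@H](CC1CCCCC1)NS(=O)(=O)Cc1ccccc1)C2` differs from compound 1 by a group of 11 heavy atoms (8 carbon, 3 nitrogen; one six-membered non-aromatic ring of carbon only, one six-membered aromatic ring with 2 hetero atoms) in place of a group of 10 heavy atoms (8 carbon, 2 nitrogen; one five-membered aromatic ring with 2 hetero atoms, one six-membered non-aromatic ring of carbon only), on an amide-type nitrogen. Going by the values given here, no measured step bears on this exchange beyond the unreadable one from compound 1 to compound 2, and both measured compounds sit at the weak end of the scale. The step from compound 1 to compound 3 in this assay is therefore expected to be small or not beyond the scatter, and the expected step is a step that the limit leaves unreadable from compound 1 to compound 3. For compound 3 in this assay the estimate is 120000 nM, expected within 25000 nM to 600000 nM.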

Compound 3, inhibition constant: > 68300 nM
Compound 3 ended at the assay's limit; the forecaster's own chance of this, stated with the estimate: 50%; the middle value does not contradict the limit.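

In this assay compound 3 gives > 68300 nM, which is a limit of the assay and not a number. No new step can be read from compound 3 to compound 1 or to compound 2, because the comparison rests on this value: the limit of > 68300 nM in this assay, at which 2 of the 3 values shown sit.

The compounds shown leave open how strongly compound 1 and compound 3 truly inhibit, and whether exchanging the group on the amide-type nitrogen changes inhibition at all.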